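Replacing 4-methoxyphenyl with 1H-indol-4-yl in compound 2

The compounds below may be only part of what the source reports. "The series", "measured", "known", "first", "only" and "open" are said of these compounds alone.

In a functional assay on DU-145 cells (Homo sapiens) for inhibition, read by trypan blue exclusion, with a stated time of 72 h (on this read-out higher numbers stand for weaker inhibition and lower numbers for stronger inhibition), compound 1 `COc1ccc(Nc2ncc3cc(S(=O)(=O)c4ccc(C)cc4)c(=O)n(C)c3n2)cc1` gives 100000 nM as its number, while compound 2 `COc1ccc(Nc2ncc3cc(S(=O)(=O)c4ccc(Cl)cc4)c(=O)n(C)c3n2)cc1` gives 30000 nM and stands level with compound 3 `Cn1c(=O)c(S(=O)(=O)c2ccc(F)cc2F)cc2cnc(Nc3ccc4[nH]ncc4c3)nc21` at 30000 nM as the lowest of the three numbers. For the measured compounds named here, the only measured step, a 3.3-fold lower number from compound 1 to compound 2 (0.52 log units; beyond the scatter) with chloro in place of methyl on an aromatic carbon, lies beyond the scatter, but it concerns a different place in the molecule. Compound 4 `Cn1c(=O)c(S(=O)(=O)c2ccc(Cl)cc2)cc2cnc(Nc3cccc4[nH]ccc34)nc21` brings the change 1H-indol-4-yl in place of 4-methoxyphenyl on a nitrogen on an aromatic ring in which 1H-indol-4-yl stands in place of 4-methoxyphenyl on a nitrogen on an aromatic ring. Going by the values given here, no measured step covers this exchange directly. Compound 2 also differs at that nitrogen from the nearest guide, compound 3, which still gives 30000 nM as its number. An estimated 1.5-fold lower number from compound 2 to compound 4 (0.18 log units; within the scatter) would therefore stay within the scatter, so no clear step is expected. In this assay compound 4 is expected at 20000 nM with an estimated range of 4000 nM to 100000 nM around that figure.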

Compound 4, half-maximal inhibitory concentration: 5000 nM
Compound 4: the middle estimate sits 4.0-fold (0.60 log units) above what was measured; the measured number falls inside the stated range.
By their numbers in this assay, from the lowest: compound 4; then compounds 2 and 3 (each within the scatter of the next); then compound 1.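

For the compounds shown here, with 1H-indol-4-yl in place of 4-methoxyphenyl on a nitrogen on an aromatic ring, this assay shows a 6.0-fold lower number from compound 2 to compound 4 (0.78 log units; beyond the scatter), so the group at this position, which no earlier step covered, can move the number beyond the scatter while the chloro stays in place. The exchange adds a five-membered aromatic ring with 1 hetero atom and replaces 1 hydrogen-bond acceptor with 1 hydrogen-bond donor, but a single step cannot show which of these differences matters. Nothing available explains the change in the number. On these data alone, it remains open whether the same exchange would give a similar step in compound 1, with methyl in place of the chloro. Also open, as far as these compounds go, is how an amine or a carboxylic acid on the aromatic ring at this position would compare with 1H-indol-4-yl.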